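The source may report more compounds than this note shows. Statements on the series, on what has been measured and on what is new or still open speak of the compounds shown alone.

Measured in a functional assay on PC-3 cells (Homo sapiens) for cytotoxicity, read by MTT assay, with a stated time of 48 h; a higher number here means a weaker inhibitor, a lower number a stronger inhibitor:
Compound 1 `COc1ccc(/C=C/C(=O)/C=C/c2cc3ccccc3nc2Oc2ccccc2)c(OC)c1`: > 10000 nM (a limit)
Compound 2 `COc1ccc(/C=C/C(=O)/C=C/c2cc3ccccc3nc2Oc2ccccc2)cc1OC`: > 10000 nM (a limit)

Neither entry is a true number. Compound 2 stands at the limit of > 10000 nM in this assay, at which 2 of the 2 values shown sit. Compound 3 `COc1ccc(/C=C/C(=O)/C=C/c2cc3ccccc3nc2Oc2ccc(Br)cc2)cc1OC` differs from compound 2 in one place, where phenoxy becomes 4-bromophenoxy: bromo in place of hydrogen on an aromatic carbon.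

Going by the values given here, the only measured step is a step that the two limits leave unreadable from compound 1 to compound 2. Among the compounds with values here, it concerns the dimethoxyphenyl group, not the phenoxy group, and no measured compound carries a bromo group. The data therefore give no size or direction to carry over to this change in this assay. The expectation starts from compound 2, whose limit is > 10000 nM. No clear step is expected, and another limit is the likeliest result. The expected change is a step that the limit leaves unreadable from compound 2 to compound 3. For compound 3, the estimated value is 12000 nM, with an expected range from 4000 nM to 30000 nM.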

Compound 3, half-maximal inhibitory concentration: > 10000 nM
Compound 3: only a limit was reported (the forecaster's own chance of this, stated with the estimate: 65%); the middle value does not contradict the limit.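

No step can be read from compound 2 to compound 3 in this assay: both entries are limits, not true numbers. The compounds shown leave open whether bromo in place of hydrogen changes the potency at all, and which change to the shared core would give a true number in this assay.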